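Hydroxyl at the chain end of a triazole series

The compounds below may be only part of what the source reports. "The series", "measured", "known", "first", "only" and "open" are said of these compounds alone.

Compound 1 `CCCCCCc1cn(C(c2ccccc2)c2cc3cc(Br)ccc3nc2OC)nn1`: 6.08%
Compound 2 `COc1nc2ccc(Br)cc2cc1C(c1ccccc1)n1cc(-c2ccccc2F)nn1`: 14.7%
Compound 3 `CCCCCc1cn(C(c2ccccc2)c2cc3cc(Br)ccc3nc2OC)nn1`: 5.07%

All three compounds were tested in an ADME assay on PANC-1 cells (Homo sapiens) for cytotoxicity, read by sulforhodamine B assay, with a stated time of 48 h, tested at 10 uM; a higher number here means more inhibition at the concentration tested (going by the name of the read-out), a lower number less inhibition. Compound 3 gives the lowest of the three numbers, yet it sits close to compound 1, and the gap to compound 2 is also within the scatter, so none of the three numbers can be called higher or lower than another.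

Compound 4 `COc1nc2ccc(Br)cc2cc1C(c1ccccc1)n1cc(CCCCCO)nn1` has not been measured. It differs from compound 3 only in one place: hydroxy in place of hydrogen on a saturated chain carbon, five bonds along the chain from an aromatic carbon.

Among the compounds with values here, no measured step adds a hydroxy group, so the closest guide is the step at the same position, a number 1 percentage points lower from compound 1 to compound 3 (within the scatter), which shows that changing the chain there left the read-out unmoved. The larger change from an alkyl chain to an aromatic ring, a number 8.6 percentage points higher from compound 1 to compound 2 (within the scatter) and a number 9.6 percentage points lower from compound 2 to compound 3 (within the scatter), also stayed within the scatter. On this evidence the expected step of a number 0.1 percentage points lower from compound 3 to compound 4 (within the scatter) in this assay is none beyond the scatter.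

Compound 4 is therefore estimated at 5%, with a range from -5% to 16%.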

Compound 4, a percentage reported as inhibition, at one concentration (the size of the read-out at that concentration, not a potency): 19.6%
Beside the measured number, compound 4's estimate is 14.6 percentage points below it; the measured number lies above the stated range.
By their numbers in this assay, from the lowest: compounds 3, 1, 2 and 4 (each within the scatter of the next, the first and the last beyond it).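

Within the data shown here, at the chain end, five bonds along the chain from an aromatic carbon, the earlier compounds showed only that removing a methyl left no readable change, whereas hydroxy in place of hydrogen gives a number 14.5 percentage points higher from compound 3 to compound 4 (beyond the scatter) in this assay, the first step in this set to pass the scatter. Hydroxy in place of methyl at that same place agrees, with a number 13.5 percentage points higher from compound 1 to compound 4 (beyond the scatter), so both plain alkyl chains, hexyl and pentyl, stand apart from the 5-hydroxypentyl chain, while 5-hydroxypentyl in place of 2-fluorophenyl gives a number 4.9 percentage points higher from compound 2 to compound 4 (within the scatter), which leaves compound 4 and compound 2 unseparated. Nothing measured here on these compounds accounts for the step, so the result remains an observation without an explanation.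

On these data alone, it stays open whether the rise needs a hydroxy group at all, or whether an amine, a carboxylic acid or a methyl ether at the chain end would give the same reading, and whether 3-hydroxypropyl or a longer chain ending in hydroxy would match 5-hydroxypentyl. Each number also comes from a single concentration, so these compounds leave potency itself unknown.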